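The source may report more compounds than this note shows. Statements on the series, on what has been measured and on what is new or still open speak of the compounds shown alone.

Three compounds share one core and differ only in the group attached to a saturated ring carbon. Compound 1 `N#CC1=C(N)N(c2ccc(S(N)(=O)=O)cc2)C2=C(C(=O)CCC2)C1/C=C/c1ccccc1` gives 45% in a functional assay on Ehrlich cells (Mus musculus) for antiproliferative activity, read by trypan blue exclusion, with a stated time of 2 h, tested at 100 ug/mL; on this read-out higher numbers stand for a stronger effect at the one concentration tested and lower numbers for a weaker effect. Compound 2 `COc1cc(CC2C(C#N)=C(N)N(c3ccc(S(N)(=O)=O)cc3)C3=C2C(=O)CCC3)ccc1O` gives 100% in this assay, and compound 3 `N#CC1=C(N)N(c2ccc(S(N)(=O)=O)cc2)C2=C(C(=O)CCC2)C1c1c(O)ccc2ccccc12` gives 15% in this assay. Compound 3 thus stands lowest of the three: the step of a number 30 percentage points lower from compound 1 to compound 3 (beyond the scatter) and the step of a number 85 percentage points lower from compound 2 to compound 3 (beyond the scatter) both lie beyond the scatter, while a number 55 percentage points higher from compound 1 to compound 2 (beyond the scatter) runs the other way. Compound 4 `COc1ccc2ccccc2c1C1C(C#N)=C(N)N(c2ccc(S(N)(=O)=O)cc2)C2=C1C(=O)CCC2` keeps the framework of compound 3 and differs from it in one place: methyl in place of hydrogen on an oxygen on an aromatic ring. Among the measured compounds shown here, none of the measured steps concerns this kind of change; all three swap the whole group on the saturated ring carbon, so they offer no guide to capping a hydroxy with a methyl. With nothing to lean on, compound 4 is expected to read close to its measured neighbour, the step of a number 5 percentage points higher from compound 3 to compound 4 (within the scatter) staying within the scatter. Compound 4 is therefore estimated to give 20%, between 5% and 45%, in this assay.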

Compound 4, a percentage reported as activity, at one concentration (the size of the read-out at that concentration, not a potency): 80%
Compound 4: the middle estimate sits 60 percentage points below what was measured; measured number outside the range, above it.
By their numbers in this assay, from the lowest: compound 3; then compound 1; then compound 4; then compound 2.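

Adding a single methyl to the oxygen on the aromatic ring, turning hydroxy into methoxy, produces a large step in this assay: a number 65 percentage points higher from compound 3 to compound 4 (beyond the scatter). This means that at this position the small cap on the oxygen can decide the reading, and the group on the saturated ring carbon cannot be judged by its overall shape alone: 2-methoxynaphthalen-1-yl reads well above 2-phenylethenyl, with a number 35 percentage points higher from compound 1 to compound 4 (beyond the scatter), yet short of 4-hydroxy-3-methoxybenzyl, with a number 20 percentage points lower from compound 2 to compound 4 (beyond the scatter). No measurement offered here accounts for the jump.

As far as these compounds go, whether ethyl, a longer chain or benzyl on the same oxygen would keep this gain remains open. So does whether an amine in place of the hydroxy would behave like the methoxy.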